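This account rests on a few compounds, and the source may have more. Where it says the series, first, only, none or still open, it means among the compounds named here.

Going by the values given here, in a functional assay on the whole organism for antagonist activity, with Rattus norvegicus as the target (on this read-out higher numbers stand for an effect only at larger amounts of compound and lower numbers for an effect already at smaller amounts), compound 1 `c1ccc2c(c1)CCC2CCN1CCN(c2cccc3c2OCCO3)CC1` gives 1.29 mg/kg and compound 2 `c1ccc2c(c1)CC(CCN1CCN(c3cccc4c3OCCO4)CC1)C2` gives 0.27 mg/kg, so compound 2 holds the lower of the two numbers measured so far. The gap between them, a 4.8-fold lower number from compound 1 to compound 2 (0.68 log units; beyond the scatter), lies beyond the scatter and goes with one change: 2,3-dihydro-1H-inden-2-yl in place of 2,3-dihydro-1H-inden-1-yl. Compound 3 `C1=C(CCN2CCN(c3cccc4c3OCCO4)CC2)c2ccccc2C1` differs from compound 2 only in this same part of the molecule: a group of 9 heavy atoms (9 carbon; one five-membered non-aromatic ring of carbon only, one six-membered aromatic ring of carbon only) in place of a group of 9 heavy atoms (9 carbon; one five-membered non-aromatic ring of carbon only, one six-membered aromatic ring of carbon only), on a saturated chain carbon, two bonds along the chain from an amine nitrogen in a ring. The new group has no common name, and its distinguishing feature is a double bond outside the aromatic ring. Among the compounds with values here, no measured compound carries such a double bond, so the data cannot show directly what it does. Within the data shown here, the only guide is the step to compound 2 a 4.8-fold lower number from compound 1 to compound 2 (0.68 log units; beyond the scatter), which shows that this assay can tell such groups apart. Drawn side by side, the entering group looks more like the group of compound 1 than that of compound 2. A modest move toward a higher number is therefore expected, estimated as a 2.6-fold higher number from compound 2 to compound 3 (0.41 log units; beyond the scatter). For compound 3 the estimate is 0.7 mg/kg, with an expected range of 0.22 mg/kg to 2.2 mg/kg.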

Compound 3, dose for 50% inhibition: 0.45 mg/kg
Compound 3: middle estimate off by 1.6-fold (0.19 log units), on the high side; the measured number falls inside the stated range.
By their numbers in this assay, from the lowest: compounds 2 and 3 (each within the scatter of the next); then compound 1.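

The group with the double bond outside the aromatic ring is tolerated at this position, on a saturated chain carbon, two bonds along the chain from an amine nitrogen in a ring: in this assay, the step from the saturated 2,3-dihydro-1H-inden-2-yl group cannot be told apart from repeat-measurement noise (a 1.7-fold higher number from compound 2 to compound 3 (0.22 log units; within the scatter)). The earlier pair showed that this assay separates two groups of the same size and ring types, and compound 3 adds a second such separation, since its group, although it looks more like that of compound 1 when drawn, gives a result clearly apart from compound 1 (a 2.9-fold lower number from compound 1 to compound 3 (0.46 log units; beyond the scatter)). No independent measurement bears on why these groups give these results.

The compounds shown leave open whether the result at this position depends on the fused pair of rings at all, as a plain phenyl or cyclohexyl group in the same place could show. They also leave open how a 1,2,3,4-tetrahydronaphthalen-2-yl group, with its larger saturated ring, or a longer chain to the amine nitrogen would read in this assay.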